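The source may hold more compounds than are shown below. What is called first, only, known or untested is meant among the compounds shown, and "the series" means these compounds.

Of the compounds shown here, three that share one core have so far been tested in a functional assay on MCF7 cells (Homo sapiens) for cytotoxicity, read by MTT assay, with a stated time of 48 h; a higher number here means a weaker inhibitor, a lower number a stronger inhibitor. Compound 1 `OC[C@@H]1C[C@H](CO)[C@@H]2C(c3ccccc3Cl)=NO[C@H]12` carries a chloro-substituted aromatic ring. In this assay compound 1 gives > 50 ug/mL, which is a limit of the assay and not a number. Compound 2 `COc1ccc(C2=NO[C@@H]3[C@H](CO)C[C@H](CO)[C@H]23)cc1OC` carries a dimethoxy-substituted ring. In this assay compound 2 gives > 50 ug/mL, again a limit rather than a measured number. Compound 3 `OC[C@@H]1C[C@H](CO)[C@@H]2C(c3ccc(F)cc3)=NO[C@H]12` carries a fluoro group on its aromatic ring. In this assay compound 3 gives > 50 ug/mL, also a limit. On the numbers shown, compound 3 sits at the limit of > 50 ug/mL in this assay, at which 3 of the 3 values shown sit, so nothing separates the three compounds from one another.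

Compound 4 `N#Cc1ccc(C2=NO[C@@H]3[C@H](CO)C[C@H](CO)[C@H]23)cc1` has not yet been measured. It differs from compound 3 by cyano in place of fluoro on an aromatic carbon. For the measured compounds named here, no step between two measured compounds is known, and every value so far is a limit, so the measurements give no size or direction to lean on. The expected step that the limit leaves unreadable from compound 3 to compound 4 is essentially none, nothing beyond the scatter. Compound 4 is estimated at 70 ug/mL, with a range from 25 ug/mL to 200 ug/mL, and the assay is most likely to report only a limit once more.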

Compound 4, half-maximal inhibitory concentration: > 50 ug/mL
Compound 4 ended at the assay's limit; the forecaster's own chance of this, stated with the estimate: 80%; the middle value does not contradict the limit.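

In this assay compound 4 gives > 50 ug/mL, which is a limit and not a number. No step from compound 3 to compound 4 can therefore be read, and the four compounds cannot be told apart: the limit of > 50 ug/mL in this assay, at which 4 of the 4 values shown sit.

The compounds shown leave open whether any group on the aromatic ring of the shared core gives a measurable value in this assay.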